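A Bromine Removed from the Pyrazoline Series

A few compounds are considered here, and "the series" means these few. Any claim that something is new, unique, unknown or untested is made for them only; others in the source may bear on it.

Of the compounds shown here, two have been measured in a functional assay on WM 266-4 cells (Homo sapiens) for inhibition, read by MTT assay, with a stated time of 24 h; on this read-out higher numbers stand for weaker inhibition of growth and lower numbers for stronger inhibition of growth. Compound 1 `O=C(C1COc2ccccc2O1)N1N=C(c2ccc(Br)cc2)CC1c1ccccc1F` gives 8030 nM, the highest of the two numbers. Compound 2 `O=C(c1ccc2c(c1)OCCO2)N1N=C(c2ccc(Br)cc2)CC1c1ccccc1F` gives 580 nM in this assay. Among the measured compounds shown here, the one step between them, a 14-fold lower number from compound 1 to compound 2 (1.14 log units; beyond the scatter), is large and concerns the group on the carbonyl carbon, with 2,3-dihydro-1,4-benzodioxin-6-yl in place of 2,3-dihydro-1,4-benzodioxin-2-yl.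

Compound 3 `O=C(C1COc2ccccc2O1)N1N=C(c2ccccc2)CC1c1ccccc1F` is not yet measured. It differs from compound 1 in a different place: hydrogen in place of bromo on an aromatic carbon. For the measured compounds named here, the only measured step touches the carbonyl side and says nothing about the bromine on the aromatic ring, so no measured step bears on this change. The expectation therefore rests on the structural change alone, and the step is expected to be modest: a 1.5-fold higher number from compound 1 to compound 3 (0.17 log units; within the scatter), with a wide range to allow for either direction. For compound 3 the estimate in this assay is 12000 nM, with a range from 4000 nM to 36000 nM.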

Compound 3, concentration for 50% growth inhibition: 1490 nM
For compound 3 the middle estimate is 8.1-fold (0.91 log units) above the measured one; the whole stated range lies above it.
By their numbers in this assay, from the lowest: compound 2; then compound 3; then compound 1.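

Removing the bromine is not a neutral change at this position: in this assay, hydrogen in place of bromo gives a 5.4-fold lower number from compound 1 to compound 3 (0.73 log units; beyond the scatter). With the 2,3-dihydro-1,4-benzodioxin-2-yl group kept on the carbonyl carbon, the plain phenyl compound therefore inhibits growth more strongly than its 4-bromophenyl counterpart, which shows that the bromine is not needed for activity in this pair and that its removal helps here. Among the compounds shown here, the earlier step spoke only about the carbonyl side, so this is the first sign that the aromatic carbon para to a large group also affects the read-out, although nothing available explains why the number falls.

From the compounds shown here alone, it remains open whether the same change would act in the same direction and to a similar extent on compound 2, which carries the 2,3-dihydro-1,4-benzodioxin-6-yl group on the carbonyl carbon. Going by these compounds, it is also open how other groups at this aromatic carbon, such as a chlorine, a methoxy group or an amine, would compare with hydrogen and bromo.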